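A few compounds are considered here, and "the series" means these few. Any claim that something is new, unique, unknown or untested is made for them only; others in the source may bear on it.

Measured so far:
compound 1 `Cc1nc(-c2ccccc2)sc1C(=O)CSc1nc(-c2ccc(Cl)c(Cl)c2)c(C#N)c(=O)[nH]1` — 75.3%
compound 2 `COc1ccc(-c2nc(SCC(=O)c3sc(-c4ccc(Cl)cc4)nc3C)[nH]c(=O)c2C#N)cc1` — 46.3%
compound 3 `COc1ccc(-c2nc(SCC(=O)c3sc(-c4ccc(Cl)cc4)nc3C)[nH]c(=O)c2C#N)cc1OC` — 59.8%

In a functional assay on U-87MG ATCC cells for antiproliferative activity against U-87 MG (Homo sapiens), read by MTT assay, with a stated time of 48 h, tested at 50 uM (a higher number here means a weaker effect of the compound at the concentration tested, a lower number a stronger effect), compound 1 gives the highest of the three numbers. Compound 2 and compound 3 share a core; the difference between that core and the core of compound 1 is not broken down here. From compound 2 to compound 3 the change is methoxy in place of hydrogen on an aromatic carbon, and it made a number 13.5 percentage points higher from compound 2 to compound 3 (beyond the scatter).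

Compound 4 `COc1ccc(-c2nc(C)c(C(=O)CSc3nc(-c4ccc(Cl)c(Cl)c4)c(C#N)c(=O)[nH]3)s2)cc1` is not yet measured. It differs from compound 1 by methoxy in place of hydrogen on an aromatic carbon. This is the same kind of change as from compound 2 to compound 3, but not the same: there the methoxy entered ortho to a methoxy group and meta to a large group, here it enters para to a large group.

Resting on the step from compound 2 to compound 3 in this assay, compound 4 is expected to give a step of a number 7.7 percentage points higher from compound 1 to compound 4 (within the scatter). The estimated result for compound 4 is 83%, expected between 68% and 96%.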

Compound 4, a percentage reported as activity, at one concentration (the size of the read-out at that concentration, not a potency): 78.4%
For compound 4 the middle estimate is 4.6 percentage points above the measured one, within the range that was stated.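

In this assay, methoxy in place of hydrogen gave a number 3.1 percentage points higher from compound 1 to compound 4 (within the scatter), and the two cases of this change can be set side by side: the same change on two cores in this assay, a number 13.5 percentage points higher (beyond the scatter) from compound 2 to compound 3 and a number 3.1 percentage points higher (within the scatter) from compound 1 to compound 4, 10.4 percentage points apart, within the scatter of two such steps The two steps therefore do not separate, and nothing here shows that the change behaves differently on the two cores. Nor does this show that the change carries over unaltered, since only two pairs are available, the methoxy enters at a different place in each, and only one step lies beyond the scatter.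

The compounds shown leave open how an amine or a carboxylic acid would read in place of the methoxy on the phenyl. They also leave open how the methoxy change would read on a third core.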